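Sulfonyl substituent in a dihydropyrazole series: methyl to aryl

The source may hold more compounds than are shown below. What is called first, only, known or untested is meant among the compounds shown, and "the series" means these compounds.

Compound 2 `CN(C)c1ccc(C2CC(c3ccc(-n4cncn4)cc3)=NN2S(C)(=O)=O)cc1` gives 7.8% in a functional assay on MDA-MB-231 cells (Homo sapiens) for inhibition, read by sulforhodamine B assay, tested at 10 uM; a higher number here means more inhibition at the concentration tested (going by the name of the read-out), a lower number less inhibition; it is the lower of the two numbers, with compound 1 `CN(C)c1ccc(C2CC(c3ccc(-n4cncn4)cc3)=NN2C(=O)c2ccc(C(F)(F)F)cc2)cc1` at 16.7% the nearest, and the step of a number 8.9 percentage points lower from compound 1 to compound 2 (within the scatter) lies within the scatter. Compound 3 `CN(C)c1ccc(C2CC(c3ccc(-n4cncn4)cc3)=NN2S(=O)(=O)c2ccc(OC(F)(F)F)cc2)cc1` differs from compound 2 by 4-(trifluoromethoxy)phenyl in place of methyl on a sulfonyl sulfur. Going by the values given here, no measured step changes a substituent on the sulfonyl sulfur, so none bears directly on it; the only step in hand, from an aryl carbonyl to methylsulfonyl, was small. A step no larger than the scatter is therefore expected, a number 7.2 percentage points higher from compound 2 to compound 3 (within the scatter), perhaps upward. Compound 3 is estimated at 15%, between 0% and 40%.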

Compound 3, a percentage reported as inhibition, at one concentration (the size of the read-out at that concentration, not a potency): 18.5%
Compound 3: the middle estimate sits 3.5 percentage points below what was measured, and the stated range covers the measured number.
By their numbers in this assay, from the lowest: compounds 2, 1 and 3 (each within the scatter of the next, the first and the last beyond it).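

Going by these compounds alone, changing the substituent on the sulfonyl sulfur moves the read-out in this assay: a number 10.7 percentage points higher from compound 2 to compound 3 (beyond the scatter) is the first step to exceed the scatter, though it is modest. At this position a 4-(trifluoromethoxy)phenyl group is accepted in place of methyl, yet compound 3 gives only 18.5% at the single concentration tested. Nothing available accounts for this step.

This one step changes the ring and its trifluoromethoxy substituent together, so their contributions stay unseparated. A plain phenyl, or a longer alkyl chain, on the sulfonyl sulfur would address this.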